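Methyl for hydrogen on the hydroxy analogue

A few compounds are considered here, and "the series" means these few. Any claim that something is new, unique, unknown or untested is made for them only; others in the source may bear on it.

Compound 3 `CCOC(=O)CC[C@H](NC(=O)c1ccc(CNc2ccc3nc(N)nc(O)c3c2)cc1)C(=O)OCC` sits at the bottom of the three measured compounds: in an assay for inhibition of Dihydrofolate reductase (Homo sapiens) (a lower number here means a less potent compound, a higher number a more potent compound, by a factor of ten per unit of this negative logarithm), compound 3 gives 6.24, against compound 1 `CCOC(=O)CC[C@H](NC(=O)c1ccc(CNc2ccc3nc(N)nc(N)c3c2)cc1)C(=O)OCC` with 7.54 and compound 2 `CCOC(=O)CC[C@H](NC(=O)c1ccc(CNc2ccc3nc(N)nc(N)c3c2C)cc1)C(=O)OCC` with 7.7. The drop a number 1.30 log units lower from compound 1 to compound 3 (beyond the scatter) fixes compound 3 well below the others. The change under study, (methyl in place of hydrogen on an aromatic carbon), yields compound 4 `CCOC(=O)CC[C@H](NC(=O)c1ccc(CNc2ccc3nc(N)nc(O)c3c2C)cc1)C(=O)OCC`. Among the compounds with values here, the one measured step of the same kind, a number 0.16 log units higher from compound 1 to compound 2 (within the scatter), stayed within the scatter, so the same small or negligible shift is expected here, giving a number 0.16 log units higher from compound 3 to compound 4 (within the scatter). Compound 4 is therefore estimated at 6.4 in this assay, with a range of 6 to 6.8.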

Compound 4, logarithm of the reciprocal of the active concentration, log(1/C): 5.57
Estimate against measurement, compound 4: 0.83 log units above, and the stated range ends above it.
By their numbers in this assay, from the lowest: compound 4; then compound 3; then compounds 1 and 2 (each within the scatter of the next).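

Methyl in place of hydrogen on this aromatic carbon now gives a number 0.67 log units lower from compound 3 to compound 4 (beyond the scatter), so its effect is not constant across the series and depends on whether the shared core carries amino or hydroxy. The two cores do not respond alike: the same change on two cores in this assay, a number 0.16 log units higher (within the scatter) from compound 1 to compound 2 and a number 0.67 log units lower (beyond the scatter) from compound 3 to compound 4, 0.83 log units apart, beyond the scatter of two such steps. Seen the other way, hydroxy in place of amino gives a number 2.13 log units lower from compound 2 to compound 4 (beyond the scatter), a larger loss with the methyl present: the same change on two cores in this assay, a number 1.30 log units lower (beyond the scatter) from compound 1 to compound 3 and a number 2.13 log units lower (beyond the scatter) from compound 2 to compound 4, 0.83 log units apart, beyond the scatter of two such steps.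

Only hydrogen and methyl appear on this carbon. On these data alone, whether ethyl or methoxy there would show the same split between the amino and hydroxy cores remains open.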